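This account rests on a few compounds, and the source may have more. Where it says the series, first, only, none or still open, it means among the compounds named here.

Measured so far in a functional assay on MCF7 cells (Homo sapiens) for cytotoxicity, read by MTT assay, with a stated time of 72 h; on this read-out lower numbers stand for stronger inhibition and higher numbers for weaker inhibition:

Compound 1 `CC(C)=C1C(=O)N(c2ccc(Cl)cc2)N(c2ccc(Cl)cc2)C1=O` gives 39600 nM
Compound 2 `O=C1C(=Cc2ccc(F)cc2)C(=O)N(c2ccc(Cl)cc2)N1c1ccc(Cl)cc1` gives 31400 nM
Compound 3 `COc1cccc(C=C2C(=O)N(c3ccc(Cl)cc3)N(c3ccc(Cl)cc3)C2=O)c1O` gives 26700 nM

The number for compound 3 lies within the usual scatter of both other compounds, so these three cannot be put in order. Compound 4 `O=C1C(=Cc2ccc(Cl)cc2Cl)C(=O)N(c2ccc(Cl)cc2)N1c1ccc(Cl)cc1` differs from compound 3 in one place, on a double-bonded chain carbon bound to a double-bonded ring carbon: 2,4-dichlorophenyl in place of 2-hydroxy-3-methoxyphenyl on a double-bonded chain carbon bound to a double-bonded ring carbon is the whole change. Going by the values given here, one measured step bears on it, an exchange of groups at that same place, and a 1.2-fold lower number from compound 2 to compound 3 (0.07 log units; within the scatter) stayed within the scatter. No shift beyond the scatter is therefore expected in this assay and no clear direction either. The estimated step is a 1.0-fold higher number from compound 3 to compound 4 (0.02 log units; within the scatter) and it is expected to stay within the scatter. For compound 4 the estimated value is 28000 nM with an expected range from 13000 nM to 55000 nM.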

Compound 4, half-maximal inhibitory concentration: > 128000 nM
Compound 4: no number, only a limit; the forecaster's own chance of this, stated with the estimate: 10%; middle value at least 4.5-fold (0.66 log units) from the limit.
By their numbers in this assay, from the lowest: compounds 3, 2 and 1 (each within the scatter of the next). At a limit, above all of these: compound 4.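

In this assay compound 4 gives > 128000 nM as a limit and not a number. With an at least 4.7-fold higher number from compound 3 to compound 4 (0.68 log units; beyond the scatter) and an at least 4.0-fold higher number from compound 2 to compound 4 (0.61 log units; beyond the scatter) on this read-out, placing 2,4-dichlorophenyl on a double-bonded chain carbon bound to a double-bonded ring carbon goes beyond the scatter, which the earlier exchange at this place did not. The true size of the shift stays hidden at this limit: the limit of > 128000 nM in this assay, at which 1 of the 4 values shown sits.

Still open, going by these compounds, is whether 4-chlorophenyl or 2-chlorophenyl alone would behave like 2,4-dichlorophenyl at this place. Also open, on these data alone, is what an aminophenyl or a carboxyphenyl group would give there.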